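Anilino in Place of Isopropyl(methyl)amino: What to Expect

This account rests on a few compounds, and the source may have more. Where it says the series, first, only, none or still open, it means among the compounds named here.

Measured so far:
- compound 1, `CN(C)c1ncnc2c1ncn2C`: 33%
- compound 2, `CN(C)c1ncnc2c1ncn2CC1CCCCC1`: 0%
- compound 3, `CC(C)N(C)c1ncnc2c1ncn2Cc1ccccc1`: 17%

The three compounds above share one core and were tested in a functional assay on the whole organism for inhibition, with Rattus norvegicus as the target, in the maximal electroshock model, at a dose of 25 mg/kg by the intraperitoneal route; on this read-out higher numbers stand for more inhibition at the one dose given (going by the name of the read-out) and lower numbers for less inhibition. Compound 3 stands second of the three: compound 1 is a number 33 percentage points lower from compound 1 to compound 2 (beyond the scatter) apart from compound 2, and compound 3 sits between them, beyond the scatter from each. Among the compounds with values here, compound 1 and compound 3 differ at two places at once, so their values show only that compound 3 is lower.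

Compound 4, `c1ccc(Cn2cnc3c(Nc4ccccc4)ncnc32)cc1`, has not yet been tested. It differs from compound 3 by anilino in place of isopropyl(methyl)amino on an aromatic carbon. Within the data shown here, the single measured step, a number 33 percentage points lower from compound 1 to compound 2 (beyond the scatter), concerns a change on a saturated chain carbon bound to an aromatic nitrogen, a different place from the one altered here, so it does not bear on this step. The record therefore gives no direct guide to how an anilino group with its one hydrogen-bond donor will behave on this aromatic carbon.

Without a matching precedent, compound 4 is expected to give 25% in this assay, with a range of 0% to 60%. The expected step from compound 3 to compound 4 is a number 8 percentage points higher from compound 3 to compound 4 (within the scatter), which may fall within the scatter.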

Compound 4, a percentage reported as inhibition, in the whole organism at one dose (the size of the read-out at that dose, not a potency): 0%
Estimate against measurement, compound 4: 25 percentage points above; the range from low to high includes it.
By their numbers in this assay, from the lowest: compounds 2 and 4 (each within the scatter of the next); then compound 3; then compound 1.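

In this assay, anilino in place of isopropyl(methyl)amino on an aromatic carbon gives a number 17 percentage points lower from compound 3 to compound 4 (beyond the scatter) and is the first single change shown at this position, since the earlier step concerned a saturated chain carbon bound to an aromatic nitrogen. The group on this aromatic carbon therefore matters for the read-out at this dose, and with anilino there compound 4 gives 0% in this test, where the benzyl-bearing compound 3 still showed some inhibition. Nothing measured here explains why the number falls.

The step changes several things at once: the group gains a six-membered aromatic ring of carbon and a hydrogen-bond donor, and it loses the isopropyl and methyl groups, so these compounds cannot say which of these differences counts. Methyl(phenyl)amino, which keeps the aromatic ring without the hydrogen on nitrogen, and cyclohexylamino, which keeps that hydrogen without the aromatic ring, would pull these apart, and whether any group on this carbon can raise the number above that of compound 3 remains open.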